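From Methoxy to Ethoxy: Compound 3 to Compound 4

The source may report more compounds than this note shows. Statements on the series, on what has been measured and on what is new or still open speak of the compounds shown alone.

Three compounds share one core and differ only in the group on a nitrogen on an aromatic ring. Compound 1 `FC(F)(F)c1ccc(CSc2nc(Nc3cccc(Cl)c3)c3ccccc3n2)cc1` gives 13400 nM in a functional assay on PC-3 cells (Homo sapiens) for cytotoxicity, read by MTT assay, with a stated time of 72 h; a lower number here means a stronger inhibitor, a higher number a weaker inhibitor; compound 2 `FC(F)(F)c1ccc(CSc2nc(Nc3ccc(C(F)(F)F)cc3)c3ccccc3n2)cc1` gives 7880 nM; compound 3 `COc1ccc(Nc2nc(SCc3ccc(C(F)(F)F)cc3)nc3ccccc23)cc1` gives 16700 nM. Compound 3 carries the highest number of the three: a 1.2-fold higher number from compound 1 to compound 3 (0.10 log units; within the scatter) keeps it within the scatter of compound 1, while a 2.1-fold higher number from compound 2 to compound 3 (0.33 log units; beyond the scatter) is a modest step beyond it. Compound 4 `CCOc1ccc(Nc2nc(SCc3ccc(C(F)(F)F)cc3)nc3ccccc23)cc1` differs from compound 3 by methyl in place of hydrogen on a saturated chain carbon bound to an oxygen on an aromatic ring. Going by the values given here, none of the measured steps touches this chain; the only one involving the methoxy, a 2.1-fold higher number from compound 2 to compound 3 (0.33 log units; beyond the scatter), replaces it with a different group altogether, so no guide exists for lengthening it. Compound 4 is therefore expected to show a 1.0-fold lower number from compound 3 to compound 4 (0.02 log units; within the scatter), an estimated 16000 nM with a range from 7000 nM to 36000 nM.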

Compound 4, half-maximal inhibitory concentration: 32100 nM
Beside the measured number, compound 4's estimate is 2.0-fold (0.30 log units) below it, within the range that was stated.
By their numbers in this assay, from the lowest: compounds 2, 1, 3 and 4 (each within the scatter of the next, the first and the last beyond it).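

Lengthening methoxy to ethoxy gives a 1.9-fold higher number from compound 3 to compound 4 (0.28 log units; within the scatter) in this assay and so cannot be told apart from no change. Still, 4-ethoxyphenyl in place of 3-chlorophenyl gives a 2.4-fold higher number from compound 1 to compound 4 (0.38 log units; beyond the scatter) and lies beyond the scatter, which 4-methoxyphenyl did not, while ethoxy in place of trifluoromethyl gives a 4.1-fold higher number from compound 2 to compound 4 (0.61 log units; beyond the scatter) as the largest step in this set. No evidence on hand accounts for these steps. Open, going by these compounds, is whether a propyl chain on this oxygen, or an amine in place of the ethoxy, would raise the number further or bring it back down.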